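The compounds below may be only part of what the source reports. "The series", "measured", "known", "first", "only" and "open" are said of these compounds alone.

Working notes on the series.

Among the measured compounds shown here, compound 2 `CCCS(=O)(=O)Nc1ccc(F)c(C(=O)c2n[nH]c3ncc(-c4ccc([N+](=O)[O-])cc4)cc23)c1F` gives 4.2% in an assay for binding affinity to dual specificity mitogen-activated protein kinase kinase 4 (Homo sapiens), read by KINOMEscan, tested at 100 nM (a lower number here means a stronger effect, a higher number a weaker effect of the compound at the concentration tested), the lowest of the two numbers measured so far. Its nearest neighbour is compound 1 `CCCS(=O)(=O)Nc1ccc(F)c(C(=O)c2n[nH]c3ncc(-c4cc(Cl)cc(Cl)c4)cc23)c1F`, which gives 73% in this assay; the step of a number 68.8 percentage points lower from compound 1 to compound 2 (beyond the scatter) is large and beyond the scatter, with 4-nitrophenyl in place of 3,5-dichlorophenyl on an aromatic carbon.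

Compound 3 `CCCS(=O)(=O)Nc1ccc(F)c(C(=O)c2n[nH]c3ncc(-c4ccc(S(N)(=O)=O)cc4)cc23)c1F` has not yet been measured. It differs from compound 2 by sulfamoyl in place of nitro on an aromatic carbon, on an aromatic carbon of a six-membered aromatic ring of carbon only, para to a large group; cut one bond further out, the difference reads 4-nitrophenyl to 4-sulfamoylphenyl. For the measured compounds named here, no measured step exchanges nitro for sulfamoyl, so the only step on record, from compound 1 to compound 2, concerns a different exchange and gives no direct guide. The sulfamoyl group brings one hydrogen-bond donor that nitro lacks, and the read-out may move in either direction; a modest rise from the low value of compound 2 is expected, though not beyond doubt. The step of a number 10.8 percentage points higher from compound 2 to compound 3 (beyond the scatter) is the estimated change in this assay. For compound 3 the estimate in this assay is 15%, within a range from 2% to 55%.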

Compound 3, a percentage reported as activity, at one concentration (the size of the read-out at that concentration, not a potency): 0.25%
For compound 3 the middle estimate is 14.8 percentage points above the measured one; measured number outside the range, below it.
By their numbers in this assay, from the lowest: compounds 3 and 2 (each within the scatter of the next); then compound 1.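

In this assay the step of a number 4 percentage points lower from compound 2 to compound 3 (within the scatter) lies within the scatter, so at this aromatic carbon, para to a large group, sulfamoyl and nitro cannot be told apart, even though sulfamoyl carries a hydrogen-bond donor and nitro carries none. The step of a number 72.8 percentage points lower from compound 1 to compound 3 (beyond the scatter) is large, so the gap that first appeared with 4-nitrophenyl against 3,5-dichlorophenyl now holds for a second group, 4-sulfamoylphenyl, and no longer rests on the nitro group alone. No measurement on hand explains why these two groups read alike or why both stand so far from 3,5-dichlorophenyl.

As far as these compounds go, it remains open whether the low read-out extends to other groups at this place, such as a 4-amino, 4-carboxylic acid or 4-methoxy substituent on the phenyl ring, or whether it is confined to the two seen here. A 4-chlorophenyl compound would show whether the high number of compound 1 goes with chlorine itself or with the 3,5-dichloro pattern, and a reading at a lower concentration could separate compound 2 from compound 3 where this single concentration does not.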